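Crown ether esters: swapping a cyclopropyl chain for phenylbutyl

A few compounds are considered here, and "the series" means these few. Any claim that something is new, unique, unknown or untested is made for them only; others in the source may bear on it.

These compounds share a large ring of oxygen-linked carbons, the crown ether core, carrying an ester whose acid part varies. Growth inhibition was measured in a functional assay on SW1573 cells (Homo sapiens) for inhibition, read by sulforhodamine B assay, with a stated time of 48 h; a higher number here means a weaker inhibitor of growth, a lower number a stronger inhibitor of growth. Compound 1, `CC(C)=CC1C(C(=O)OCC2COCCOCCOCCOCCOCCO2)C1(C)C`, gives 54000 nM in this assay. Compound 2, `O=C(CCCCCCCCCCOc1ccccc1)OCC1COCCOCCOCCOCCOCCO1`, gives 24000 nM, so compound 1 shows the higher of the two numbers, a difference beyond the usual scatter. Compound 3, `O=C(CCCCC1CCCCC1)OCC1COCCOCCOCCOCCO1`, which carries a smaller crown ring, reaches only (the limit of > 100000 nM in this assay, at which 1 of the 3 values shown sits); its result of > 100000 nM is a limit of the assay rather than a number.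

The next compound, compound 4, `O=C(CCCCc1ccccc1)OCC1COCCOCCOCCOCCOCCO1`, differs from compound 1 in one place: 4-phenylbutyl in place of 2,2-dimethyl-3-(2-methylprop-1-en-1-yl)cyclopropyl on a carbonyl carbon. The acid part thus changes from a branched three-membered ring to a straight chain ending in a benzene ring, while the crown ether core is unchanged. Only compound 2 with its longer aryl-bearing chain offers a comparison, and its number is lower than that of compound 1. Given that the change to a chain with an aromatic ring remains modest, a step of about a 1.1-fold higher number from compound 1 to compound 4 (0.05 log units; within the scatter) is expected, that is, no clear shift beyond the scatter. Compound 4 is therefore estimated at 60000 nM, with a plausible range from 20000 nM to 200000 nM.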

Compound 4, concentration for 50% growth inhibition: > 100000 nM
Compound 4 ended at the assay's limit (the forecaster's own chance of this, stated with the estimate: 30%); middle value at least 1.6-fold (0.22 log units) away from the limit.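

Placing 4-phenylbutyl in place of 2,2-dimethyl-3-(2-methylprop-1-en-1-yl)cyclopropyl on the carbonyl carbon, with the shared core unchanged, gives in this assay an at least 1.8-fold higher number from compound 1 to compound 4 (0.26 log units; that floor lies within the scatter). On these data alone, compound 4 gives > 100000 nM, which is a limit of the assay and not a number, so the true size of this step remains unknown, and the printed floor alone does not carry it beyond the scatter. This is the first direct comparison at this position, and it shows that a benzene ring at the end of a short straight chain brings no lower number than the branched cyclopropyl group, while the limit now accounts for a second result: the limit of > 100000 nM in this assay, at which 2 of the 4 values shown sit.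

As far as these compounds go, how far compound 4 lies past the limit remains open, so this single swap cannot rank the two acid parts with any precision. Also open, from the compounds shown here alone, is whether an amine or a carboxylic acid in place of 4-phenylbutyl on the same carbonyl carbon, with the core of compound 1 kept, would bring a measurable number back into range.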